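The source may hold more compounds than are shown below. What is called first, only, known or untested is meant among the compounds shown, and "the series" means these compounds.

Compound 1, `N#Cc1ccc(Cn2cncc2CNc2ccc(C(=O)Nc3cccc([N+](=O)[O-])c3)c(-c3ccccc3)c2)cc1`: in a functional assay on NIH3T3 cells (Mus musculus) (a lower number here means that less compound is needed, a higher number that more compound is needed for the effect), compound 1 gives > 10 uM, which is a limit of the assay and not a number.
Compound 2, `CSCC[C@H](NC(=O)c1ccc(CNCc2c[nH]cn2)cc1-c1ccccc1C)C(=O)O`: in this assay compound 2 gives > 25 uM, again only a limit.
Compound 3, `N#Cc1ccc(Cn2cncc2CNc2ccc(C(=O)NCc3ccccc3)c(-c3ccccc3)c2)cc1`: in this assay compound 3 gives > 10 uM, once more a limit.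

Compound 3 therefore stands at the limit of > 10 uM in this assay, at which 2 of the 3 values shown sit, and none of the three measured compounds shows a number at all; the third sits at the limit of > 25 uM in this assay, at which 1 of the 3 values shown sits. Within the data shown here, the only step between measured compounds that differ in one place, a step that the two limits leave unreadable from compound 1 to compound 3, cannot be read, since both ends are limits.

Compound 4, `N#Cc1ccc(Cn2cncc2CNc2ccc(C(=O)NCC3CCCCC3)c(-c3ccccc3)c2)cc1`, differs from compound 3 by cyclohexyl in place of phenyl on a saturated chain carbon bound to an amide-type nitrogen. Among the measured compounds shown here, no measured pair speaks to this exchange, and the one step that shares the amide-type nitrogen as its place gives no readable size. Compound 4 is expected to sit near the same limit, at an estimated 20 uM with a range from 8 uM to 60 uM. The step from compound 3 to compound 4 is thus expected to be a step that the limit leaves unreadable from compound 3 to compound 4, that is, none beyond the scatter.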

Compound 4, concentration for half-maximal effect: > 10 uM
Compound 4 was reported as a limit (the forecaster's own chance of this, stated with the estimate: 80%); the middle value does not contradict the limit.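

In this assay compound 4 gives > 10 uM, which is a limit and not a number. The steps among compound 1, compound 3 and compound 4 therefore cannot be read. The compounds shown leave open what size, if any, the exchanges on the amide-type nitrogen have.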